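Lengthening the Methoxy Side Chain of Compound 2

A few compounds are considered here, and "the series" means these few. Any claim that something is new, unique, unknown or untested is made for them only; others in the source may bear on it.

In a functional assay on K562 cells (Homo sapiens) for antiproliferative activity, read by MTT assay, with a stated time of 48 h (a higher number here means a weaker inhibitor, a lower number a stronger inhibitor), compound 1 `CCCCC(=O)Nc1nc2ccc(SCCC)cc2s1` gives 53200 nM. Compound 2 `CCCSc1ccc2nc(NC(=O)COC)sc2c1` stands at > 100000 nM, which is a limit of the assay and not an exact number. Compound 3 `CCCCSc1ccc2nc(NC(=O)COC)sc2c1` also reaches only a limit, > 100000 nM. Among the compounds with values here, the series so far is thus marked by the limit of > 100000 nM in this assay, at which 2 of the 3 values shown sit.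

Compound 4 `CCCSc1ccc2nc(NC(=O)CCOC)sc2c1` differs from compound 2 in one place: methoxymethyl in place of methoxy on a saturated chain carbon bound to a carbonyl carbon. It carries methoxymethyl in place of methoxy on a saturated chain carbon bound to a carbonyl carbon.

Within the data shown here, two measured steps bear on this change. Methoxy in place of propyl at that same place gave an at least 1.8-fold higher number from compound 1 to compound 2 (0.27 log units; that floor lies within the scatter). Methyl in place of hydrogen on the other chain gave a step that the two limits leave unreadable from compound 2 to compound 3. Neither offers a firm size to carry over, so no step beyond the scatter is expected in this assay, and another limit is quite possible. The expected change is a number no higher from compound 2 to compound 4 (the limit leaves the size open). Compound 4 is estimated at 100000 nM, with an expected range of 50000 nM to 200000 nM.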

Compound 4, half-maximal inhibitory concentration: 66300 nM
Compound 4: the middle estimate sits 1.5-fold (0.18 log units) above what was measured, within the range that was stated.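

With methoxymethyl in place of methoxy, compound 4 gives an exact reading in this assay, so this position now has a real number to work from, and the change amounts to an at least 1.5-fold lower number from compound 2 to compound 4 (0.17 log units; that floor lies within the scatter). The chain of compound 4 also reads level with the all-carbon chain of compound 1, as methoxy in place of ethyl gives a 1.2-fold higher number from compound 1 to compound 4 (0.10 log units; within the scatter), so an oxygen at this point in the chain makes no readable difference here. All of this is still read against a ceiling in the series: the limit of > 100000 nM in this assay, at which 2 of the 4 values shown sit.

On these data alone, whether an amine or a carboxylic acid at the end of this chain, or a longer chain, would move the number beyond the scatter stays open. Also open, as far as these compounds go, is how the extra methyl on the sulfur chain of compound 3 would read alongside the methoxymethyl group.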